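This account rests on a few compounds, and the source may have more. Where it says the series, first, only, none or still open, it means among the compounds named here.

Measured compounds:
Compound 1 `Clc1ccc(C2CC(c3ccccc3)=NN2c2ccc(-c3ccccc3)nn2)cc1` — 100000 nM
Compound 2 `FC(F)(F)c1ccc(C2CC(c3ccccc3)=NN2c2ccc(-c3ccccc3)nn2)cc1` — 50000 nM

In a functional assay on Caco-2 cells (Homo sapiens) for antiproliferative activity, read by MTT assay, with a stated time of 24 h (on this read-out higher numbers stand for weaker inhibition and lower numbers for stronger inhibition), compound 1 gives 100000 nM and compound 2 gives 50000 nM. Going by the values given here, of the two numbers, compound 2 carries the smaller one, but its only neighbour is compound 1, and the step of a 2.0-fold lower number from compound 1 to compound 2 (0.30 log units; within the scatter) lies within the scatter, so the two compounds are not separated by this assay.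

Compound 3 `COc1ccc(C2CC(c3ccccc3)=NN2c2ccc(-c3ccccc3)nn2)cc1` has not yet been measured. It differs from compound 2 in one place: methoxy in place of trifluoromethyl on an aromatic carbon. Among the compounds with values here, the one measured step that touches the same position is the one from compound 1 to compound 2, where a trifluoromethyl took the place of a chloro; that step, a 2.0-fold lower number from compound 1 to compound 2 (0.30 log units; within the scatter), stayed within the scatter. Within the data shown here, nothing measured here speaks to a methoxy at this position, so the only guidance is that one exchange at this carbon left this assay essentially unchanged.

Compound 3 is therefore expected to give about 50000 nM, with a range from 20000 nM to 150000 nM. The expected step of no change at the digits printed from compound 2 to compound 3 (within the scatter) is estimated to stay within the scatter.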

Compound 3, half-maximal inhibitory concentration: > 100000 nM
Compound 3: a limit, no number; the forecaster's own chance of this, stated with the estimate: 15%; at least 2.0-fold (0.30 log units) between middle value and limit.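

In this assay compound 3 gives > 100000 nM as a limit of the assay and not a number. The exchange of 4-(trifluoromethyl)phenyl for 4-methoxyphenyl, the only one of the exchanges shown that places an oxygen on this carbon, gives an at least 2.0-fold higher number from compound 2 to compound 3 (0.30 log units; that floor lies within the scatter) and so its floor does not by itself separate the two compounds, although methoxy is the one group of the three at this position that yields no readable number. The exchange of chloro for methoxy gives a number no lower from compound 1 to compound 3 (the limit leaves the size open), and the measurements at this carbon now reach the end of what the assay reports: the limit of > 100000 nM in this assay, at which 1 of the 3 values shown sits.

Whether any group at this carbon can move the number beyond the scatter towards stronger inhibition stays open, since only chloro, trifluoromethyl and methoxy are shown there. An amine, a carboxylic acid or a longer alkoxy chain at this carbon could test that, and the compounds shown say nothing about changes elsewhere on the shared core.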